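This account rests on a few compounds, and the source may have more. Where it says the series, first, only, none or still open, it means among the compounds named here.

Measured compounds in this series:
compound 1 `CCCCCSc1nc(C(F)(F)F)ccc1CNC(=O)C(C)c1ccc(NS(C)(=O)=O)c(F)c1` — 95.6 nM
compound 2 `CC(C(=O)NCc1ccc(C(F)(F)F)nc1SCCOc1ccccc1)c1ccc(NS(C)(=O)=O)c(F)c1` — 118 nM
compound 3 `CC(C(=O)NCc1ccc(C(F)(F)F)nc1SCCCN1CCCCC1)c1ccc(NS(C)(=O)=O)c(F)c1` — 250 nM

All three were read in an assay on CHO-K1 cells for antagonist activity at transient receptor potential cation channel subfamily V member 1 (Homo sapiens), read by FLIPR; a lower number here means a stronger inhibitor, a higher number a weaker inhibitor. Compound 3 gives the highest number of the three: against compound 2 the step is a 2.1-fold higher number from compound 2 to compound 3 (0.33 log units; beyond the scatter), against compound 1 it is a 2.6-fold higher number from compound 1 to compound 3 (0.42 log units; beyond the scatter), both beyond the scatter, whereas compound 1 and compound 2 sit within the scatter of each other (a 1.2-fold higher number from compound 1 to compound 2 (0.09 log units; within the scatter)).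

Compound 4 `COC(=O)CCSc1nc(C(F)(F)F)ccc1CNC(=O)C(C)c1ccc(NS(C)(=O)=O)c(F)c1` has not yet been measured in this assay. The change from compound 3 is methoxycarbonyl in place of (piperidin-1-yl)methyl on a saturated chain carbon, two bonds along the chain from a sulfur. The two steps that bear on it are the ones arriving at the (piperidin-1-yl)methyl group of compound 3, from compound 1 and from compound 2, both modest and both toward a higher number. Compound 4 removes that group again and puts in a shorter chain end without ring, so the expected direction is back toward the numbers of compounds 1 and 2, with a step of roughly the same modest size, a 2.1-fold lower number from compound 3 to compound 4 (0.32 log units; beyond the scatter). Among the compounds with values here, only two prior steps inform this, so the range is kept wide. For compound 4 the estimate in this assay is 120 nM, expected to fall between 50 nM and 300 nM.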

Compound 4, half-maximal inhibitory concentration: 1100 nM
Compound 4: the middle estimate sits 9.2-fold (0.96 log units) below what was measured; the whole stated range lies below it.
By their numbers in this assay, from the lowest: compounds 1 and 2 (each within the scatter of the next); then compound 3; then compound 4.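

In this assay, this place on a saturated chain carbon, two bonds along the chain from a sulfur, proves more sensitive than the earlier chain ends suggested: methoxycarbonyl gives a 4.4-fold higher number from compound 3 to compound 4 (0.64 log units; beyond the scatter), and the comparisons with the other two chain ends give a 9.3-fold higher number from compound 2 to compound 4 (0.97 log units; beyond the scatter) and a 12-fold higher number from compound 1 to compound 4 (1.06 log units; beyond the scatter). Having no ring does not separate these results, since compound 1 also has no ring in this chain and gives 95.6 nM, whereas the methoxycarbonyl end of compound 4 moves the number well beyond the scatter. The data shown contain no independent measurement that explains this shift.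

The compounds shown do not separate the contribution of the methoxycarbonyl group from that of the shorter chain carrying it, and a longer chain ending in methoxycarbonyl would address that question. A carboxylic acid or a primary amide at the same chain end would show whether the higher number extends to other carbonyl groups or is confined to this one.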